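The source may report more compounds than this note shows. Statements on the series, on what has been measured and on what is new or still open speak of the compounds shown alone.

In an in vitro ADME assay on microsomes (Homo sapiens) for metabolic stability (on this read-out lower numbers stand for a shorter-lived compound and higher numbers for a longer-lived compound), compound 3 (`CCc1nc(-c2ccc(Cl)cc2Cl)c(CC)nc1NC(COC)COC`) gives 0.15 h. Compound 1 (`CCc1nc(-c2ccc(OC)cc2OC(F)(F)F)c(CC)nc1NC(CC)CC`), at 0.267 h, lies within the scatter of compound 3, whereas compound 2 (`CCc1nc(NC(CC)CC)cnc1-c1ccc(Cl)cc1Cl`), at 0.467 h, stands higher than compound 3 by more than the scatter. Compound 4 (`CCc1nc(N(CC2CC2)CC2CC2)c(CC)nc1-c1ccc(Cl)cc1Cl`) carries bis(cyclopropylmethyl)amino in place of (2-methoxy-1-(methoxymethyl)ethyl)amino on an aromatic carbon. Within the data shown here, no measured pair isolates this change, so the data offer no direct guide to its size, and no shift beyond the scatter is expected. The expected step, slightly upward and within the scatter, is a 1.3-fold higher number from compound 3 to compound 4 (0.12 log units; within the scatter). For compound 4 the estimated half-life is 0.2 h, with an expected range of 0.08 h to 0.5 h.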

Compound 4, half-life: 0.133 h
Estimate against measurement, compound 4: 1.5-fold (0.18 log units) above; measured number inside the range.
By their numbers in this assay, from the lowest: compounds 4, 3, 1 and 2 (each within the scatter of the next, the first and the last beyond it).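

In this assay, bis(cyclopropylmethyl)amino in place of (2-methoxy-1-(methoxymethyl)ethyl)amino gives a 1.1-fold lower number from compound 3 to compound 4 (0.05 log units; within the scatter) on the aromatic carbon para to the 2,4-dichlorophenyl group. This exchange removes both oxygens and the hydrogen-bond donor and brings in two three-membered rings, yet compound 3 and compound 4 cannot be told apart on this read-out. No measured evidence bears on why this is so. On these data alone, whether a morpholine or a longer alkyl chain on this carbon would shift the half-life beyond the scatter remains open.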